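A chloro group added to compound 3

The source may hold more compounds than are shown below. What is called first, only, known or untested is meant among the compounds shown, and "the series" means these compounds.

Within the data shown here, in a functional assay on NCI-H460 cells (Homo sapiens) for inhibition, read by MTT assay, with a stated time of 24 h, tested at 10 ug/mL (on this read-out lower numbers stand for less inhibition of growth and higher numbers for more inhibition of growth at the one concentration tested), compound 3 (`CC(=O)SCCC(CCCCC(=O)Nc1ccccc1)SC(C)=O`) gives 14.2% and sits at the low end of the three numbers so far. It shares that low end with compound 1 (`O=C(CCCCC1CCSS1)Nc1ccccc1Cl`), which gives 14.6% in the same measurement series. These two readings lie within the usual scatter of each other, so they cannot be told apart. Compound 2 (`O=C(CCCCC(S)CCS)Nc1ccc(Br)cn1`) gives 39.3% and stands beyond the scatter from compound 3.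

The next compound to be tested is compound 4 (`CC(=O)SCCC(CCCCC(=O)Nc1cccc(Cl)c1)SC(C)=O`). It keeps the structure of compound 3 apart from one change on the aromatic ring: chloro in place of hydrogen on an aromatic carbon. Among the measured compounds shown here, no two measured compounds differ in just one place, so this change has no direct precedent here. For the measured compounds named here, the only hint is compound 1, which also carries a chloro group on its ring and reads 14.6% without any high result. In this assay I therefore expect no step beyond the scatter, with at most a slight upward drift. The estimated step is a number 2.8 percentage points higher from compound 3 to compound 4 (within the scatter) and would remain within that scatter. Compound 4 is expected to read about 17% (estimated range 6% to 32%) when measured.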

Compound 4, percent growth inhibition at one concentration: 2.09%
Compound 4: the middle estimate sits 14.9 percentage points above what was measured; the whole stated range lies above it.
By their numbers in this assay, from the lowest: compound 4; then compounds 3 and 1 (each within the scatter of the next); then compound 2.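

In this assay, among these compounds, the change from phenyl to 3-chlorophenyl gives the first step in this set between two compounds that differ in one place, and it goes downward, a step of a number 12.1 percentage points lower from compound 3 to compound 4 (beyond the scatter) on this read-out. A single chloro group on an aromatic carbon, meta to a large group, is therefore enough on its own to lower the inhibition of growth at the one concentration tested, with the rest of the structure unchanged. Nothing available here bears on why this single atom moves the number, so the result stands as an observation without an explanation.

One step at one place cannot show whether this drop belongs to chloro in particular, and a methoxy group or an amine at the same ring carbon would be needed to test that. Among the compounds shown here, it also remains open whether the same chloro change would lower the number on the core of compound 2, which reads highest here, as no pair in this set tests it.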